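Aryl Swap on Compound 3: Expected Vero Cytotoxicity of Compound 4

The source may report more compounds than this note shows. Statements on the series, on what has been measured and on what is new or still open speak of the compounds shown alone.

Measured compounds in an ADME assay on Vero 76 cells (Chlorocebus sabaeus) for cytotoxicity, read by MTT assay, with a stated time of 96 h; on this read-out lower numbers stand for higher toxicity in this test and higher numbers for lower toxicity in this test:
compound 1 `NS(=O)(=O)c1ccc(N2N=C(c3ccccc3)CC2c2ccccc2F)cc1` gives 28000 nM
compound 2 `Cc1ccc(C2CC(c3ccccc3)=NN2c2ccc(S(N)(=O)=O)cc2)cc1` gives 20000 nM
compound 3 `Cc1ccc(C2CC(c3ccc(OCc4ccccc4)cc3)=NN2c2ccc(S(N)(=O)=O)cc2)cc1` gives 100000 nM

Compound 3 stands highest of the three; from compound 2 the change benzyloxy in place of hydrogen on an aromatic carbon gave a 5.0-fold higher number from compound 2 to compound 3 (0.70 log units; beyond the scatter). The change from compound 2 to compound 1, (2-fluorophenyl in place of 4-methylphenyl on a saturated ring carbon), gave a 1.4-fold higher number from compound 2 to compound 1 (0.15 log units; within the scatter).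

Compound 4 `NS(=O)(=O)c1ccc(N2N=C(c3ccc(OCc4ccccc4)cc3)CC2c2ccccc2F)cc1` carries the same kind of change on compound 3, (2-fluorophenyl in place of 4-methylphenyl on a saturated ring carbon). The surroundings differ: in compound 2 the carbon is next to the ring atom that bears a large group and two ring bonds from the ring atom that bears a phenyl group; in compound 3 it is next to the ring atom that bears a 4-sulfamoylphenyl group and two ring bonds from the ring atom that bears a large group. The cores themselves differ by benzyloxy in place of hydrogen on an aromatic carbon.

The step from compound 3 to compound 4 is expected to be small, a 1.2-fold higher number from compound 3 to compound 4 (0.08 log units; within the scatter), because a 1.4-fold higher number from compound 2 to compound 1 (0.15 log units; within the scatter) lay within the scatter. Compound 4 is therefore estimated at 120000 nM in this assay, likely between 60000 nM and 250000 nM.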

Compound 4, half-maximal cytotoxic concentration: > 100000 nM
Compound 4 ended at the assay's limit (the forecaster's own chance of this, stated with the estimate: 35%); the middle value lies beyond the limit too.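

In this assay compound 4 gives > 100000 nM and this is a limit of the assay, not a number. The step for 2-fluorophenyl in place of 4-methylphenyl therefore reads only as a number no lower from compound 3 to compound 4 (the limit leaves the size open), so this swap is not shown to carry over unchanged, nor to differ: the same change on two cores in this assay, a 1.4-fold higher number (0.15 log units; within the scatter) from compound 2 to compound 1 and a number no lower (the limit leaves the size open) from compound 3 to compound 4; the limit leaves it open whether they differ. From the compounds shown here alone, the benzyloxy change can be read as an at least 3.5-fold higher number from compound 1 to compound 4 (0.55 log units; beyond the scatter) and points the same way on both cores, though its size on the second stays open: the same change on two cores in this assay, a 5.0-fold higher number (0.70 log units; beyond the scatter) from compound 2 to compound 3 and an at least 3.5-fold higher number (0.55 log units; beyond the scatter) from compound 1 to compound 4; the limit leaves it open whether they differ.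

The compounds shown leave open how an amine or a carboxylic acid in place of the benzyloxy group would read in this test.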